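Isobutyl for isopropyl in a series that stays inactive

A few compounds are considered here, and "the series" means these few. Any claim that something is new, unique, unknown or untested is made for them only; others in the source may bear on it.

Compound 1 `C=CCONC(=O)CN1C(=O)S/C(=C\c2cccc(C(=O)N[C@@H](CC(C)C)C(=O)OC)c2)C1=O`, compound 2 `C=CCONC(=O)CN1C(=O)S/C(=C\c2cccc(C(=O)N[C@H](C(=O)OC)C(C)C)c2)C1=O` and compound 3 `CC(C)[C@H](NC(=O)CNC(=O)c1cn(CC(=O)NOCc2ccccc2)c2ccccc12)C(=O)O` were tested in a functional assay on RAW264.7 cells (Mus musculus) for inhibition, read by microscopy and resazurin assay, with a stated time of 72 h; a higher number here means a weaker inhibitor, a lower number a stronger inhibitor. For compound 1 the result is only a limit, > 128000 nM. For compound 2 the result is likewise a limit, > 128000 nM. For compound 3 too only a limit is reached, > 128000 nM. All three therefore sit at the limit of > 128000 nM in this assay, at which 3 of the 3 values shown sit. Compound 1 differs from compound 2 by isobutyl in place of isopropyl on a saturated chain carbon bound to an amide-type nitrogen and a carbonyl carbon, and a step that the two limits leave unreadable from compound 2 to compound 1. Compound 4 `CC(C)C[C@H](NC(=O)CNC(=O)c1cn(CC(=O)NOCc2ccccc2)c2ccccc12)C(=O)O` is not yet measured; it differs from compound 3 by isobutyl in place of isopropyl on a saturated chain carbon bound to an amide-type nitrogen and a carbonyl carbon, the same change, while the difference between the core of compound 2 and the core of compound 3 is not broken down here. Because compound 3 stops at the limit of > 128000 nM in this assay, at which 3 of the 3 values shown sit, the expected step that the limit leaves unreadable from compound 3 to compound 4 is unreadable like the measured one. Compound 4 is estimated at 150000 nM in this assay.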

Compound 4, half-maximal inhibitory concentration: > 128000 nM
Compound 4: a limit, no number (the forecaster's own chance of this, stated with the estimate: 90%); the middle value is on the limit's open side.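

Compound 3 and compound 4 both stop at a limit rather than a number, so the step between them cannot be read: the limit of > 128000 nM in this assay, at which 4 of the 4 values shown sit.

In this assay, the compounds shown leave open whether isobutyl in place of isopropyl changes inhibition at all.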